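The source may hold more compounds than are shown below. What is called first, only, known or untested is meant among the compounds shown, and "the series" means these compounds.

Compound 3 `Nc1ncc(-c2ccccc2)c(-c2ccncc2)n1` gives 48% in a functional assay on the whole organism for inhibition, with Rattus norvegicus as the target, with stated times of 1 h and 3.5 h, at a dose of 100 mg/kg by the oral route (on this read-out lower numbers stand for less inhibition and higher numbers for more inhibition at the one dose given (going by the name of the read-out)), the highest of the three numbers measured; compound 1 `c1cc(-c2ccncn2)ccn1` gives 45%, which lies within the scatter of that result, while compound 2 `NC(=O)Nc1nccc(-c2ccncc2)n1` gives 12%, lower beyond the scatter. Going by the values given here, the only single-place step measured, a number 33 percentage points lower from compound 1 to compound 2 (beyond the scatter), concerns a ureido in place of hydrogen on an aromatic carbon and does not bear on the change now in question. Compound 4 `CC(C)(C)c1nc(N)ncc1-c1ccccc1` differs from compound 3 by tert-butyl in place of pyridin-4-yl on an aromatic carbon, the tert-butyl sitting ortho to a phenyl group and meta to an amino group. Among the compounds with values here, no measured step informs this change, so the expected step of a number 13 percentage points lower from compound 3 to compound 4 (beyond the scatter) carries wide uncertainty. Compound 4 is estimated to give 35%, within 10% to 60%.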

Compound 4, a percentage reported as inhibition, in the whole organism at one dose (the size of the read-out at that dose, not a potency): 46%
Compound 4: middle estimate off by 11 percentage points, on the low side, and the stated range covers the measured number.
By their numbers in this assay, from the lowest: compound 2; then compounds 1, 4 and 3 (each within the scatter of the next).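

Swapping pyridin-4-yl for tert-butyl on this aromatic carbon, ortho to a phenyl group, gives a number 2 percentage points lower from compound 3 to compound 4 (within the scatter) in this assay at this position. A ring at this place is therefore not required to keep the read-out: tert-butyl, with no ring and no hydrogen-bond acceptor, serves within the scatter. Nothing available explains why the two groups read alike. The compounds shown leave open whether a smaller group such as methyl, or a polar one such as a primary amine or a carboxylic acid, would fare the same here. They also leave open whether tert-butyl would still serve without the neighbouring phenyl group.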